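Moving the methoxy group on a weakly active benzamide

The compounds below may be only part of what the source reports. "The series", "measured", "known", "first", "only" and "open" are said of these compounds alone.

Compound 1 `COc1cccc(C(=O)Nc2cc(Sc3ncn[nH]3)c(O)c3ccccc23)c1`: > 100000 nM
Compound 2 `O=C(Nc1cc(Sc2ncnc3nc[nH]c23)c(O)c2ccccc12)c1ccc([N+](=O)[O-])cc1`: > 100000 nM
Compound 3 `COc1ccc(/C=C/C(=O)Nc2cc(Sc3ncn[nH]3)c(O)c3ccccc23)cc1OC`: 52500 nM

Of the compounds shown here, three sharing one core have been tested in a functional assay on MDA-MB-231 cells (Homo sapiens) for antiproliferative activity, read by MTT assay, with a stated time of 48 h; on this read-out lower numbers stand for stronger inhibition and higher numbers for weaker inhibition. For compound 1 the reading is only a limit of the assay, > 100000 nM. Compound 2 likewise gives only a limit, > 100000 nM. Compound 3 gives a number, 52500 nM. Compound 1 thus stands at the weak end of what the assay can report, as does one other compound (the limit of > 100000 nM in this assay, at which 2 of the 3 values shown sit). Compound 4 `COc1ccc(C(=O)Nc2cc(Sc3ncn[nH]3)c(O)c3ccccc23)cc1` differs from compound 1 in one group: 4-methoxyphenyl in place of 3-methoxyphenyl on a carbonyl carbon. Among the measured compounds shown here, no measured pair shows what this change does, so the expectation rests on the limit for compound 1 alone, with no direction assumed beyond the scatter. Compound 4 is expected near 100000 nM, between 40000 nM and 300000 nM, so the estimated step of a number no higher from compound 1 to compound 4 (the limit leaves the size open) is expected to sit within the scatter.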

Compound 4, half-maximal inhibitory concentration: > 100000 nM
Compound 4 gave a limit, no number (the forecaster's own chance of this, stated with the estimate: 60%); the middle value sits exactly at the limit.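

Compound 1 and compound 4 both give only a limit, so the step from one to the other cannot be read: the limit of > 100000 nM in this assay, at which 3 of the 4 values shown sit.

The compounds shown leave open whether 4-methoxyphenyl in place of 3-methoxyphenyl changes the activity at all.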